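A bromine on the core: expected activity of compound 3

The compounds below may be only part of what the source reports. "The series", "measured", "known", "first", "only" and "open" are said of these compounds alone.

Measured compounds:
compound 1 `CCn1ccc2cccc(C(c3ccc(F)cc3)n3ccnc3)c21` 62 nM
compound 2 `CCn1ccc2cccc(C(c3ccc(Br)cc3)n3ccnc3)c21` 70 nM

Both compounds share the same core and differ only on the pendant aromatic ring. In an assay for inhibition of Aromatase (Homo sapiens), using microsomes (on this read-out higher numbers stand for weaker inhibition and lower numbers for stronger inhibition), compound 1 gives 62 nM, the lowest of the two numbers, with compound 2 the nearest: a 1.1-fold higher number from compound 1 to compound 2 (0.05 log units; within the scatter). The two values therefore sit within the scatter of each other, so nothing can be said about an order between them.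

Compound 3 `CCn1ccc2cc(Br)cc(C(c3ccc(F)cc3)n3ccnc3)c21` has not been measured. It differs from compound 1 by bromo in place of hydrogen on an aromatic carbon. For the measured compounds named here, no measured step touches this position of the shared core; the only step in hand, exchanging one halogen for another on the pendant ring, was within the scatter. That step bears on the change only loosely, as it shows that a halogen elsewhere on the molecule left this assay unchanged. Going by the values given here, with no direct precedent, the expectation for this assay is no change beyond the scatter, in either direction: a 1.0-fold higher number from compound 1 to compound 3 (0.02 log units; within the scatter). Compound 3 is therefore estimated at 65 nM, with a range from 25 nM to 170 nM.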

Compound 3, half-maximal inhibitory concentration: 200 nM
For compound 3 the middle estimate is 3.1-fold (0.49 log units) below the measured one, and the stated range ends below it.
By their numbers in this assay, from the lowest: compounds 1 and 2 (each within the scatter of the next); then compound 3.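

In this assay, a bromo placed on an aromatic carbon of the shared core, meta to a large group and para to a fused ring, gives a 3.2-fold higher number from compound 1 to compound 3 (0.51 log units; beyond the scatter), so the inhibition is weaker once this hydrogen is replaced. The earlier pair showed only a halogen exchange on the pendant ring, where a 1.1-fold higher number from compound 1 to compound 2 (0.05 log units; within the scatter) left no readable difference; this position on the core is therefore the first place in the series where a change registers beyond the scatter, although the step is modest in size. No measurement in hand explains why the added bromo weakens inhibition here.

A single group at this position cannot show whether the loss belongs to bromo alone or to any replacement of the hydrogen, so a fluoro, a methoxy, an amine or a carboxylic acid on the same carbon could each give a different answer. As far as these compounds go, it also remains open whether the same bromo would give a similar step on the core of compound 2, which carries bromo rather than fluoro on the pendant ring.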